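A few compounds are considered here, and "the series" means these few. Any claim that something is new, unique, unknown or untested is made for them only; others in the source may bear on it.

In a functional assay on 786-0 cells (Homo sapiens) for inhibition, read by sulforhodamine B assay, with a stated time of 48 h (on this read-out lower numbers stand for stronger inhibition of growth and higher numbers for weaker inhibition of growth), compound 3 (`O=C(Nc1cccc(-n2cc(-c3ccncc3)c(-c3ccc(Cl)c(O)c3)n2)c1)Nc1ccc(Cl)c(Cl)c1`) gives only a limit, > 32500 nM. Compound 1 (`O=C(Nc1cccc(-n2cc(-c3ccncc3)c(-c3ccc(Cl)c(O)c3)n2)c1)Nc1cccc(C(F)(F)F)c1`) likewise gives only a limit, > 32500 nM. Compound 3 therefore stands at the limit of > 32500 nM in this assay, at which 2 of the 3 values shown sit. Compound 2 (`COc1cc(-c2nn(-c3cccc(NC(=O)Nc4ccc(Cl)c(Cl)c4)c3)cc2-c2ccncc2)ccc1Cl`) gives a true number, 4470 nM. Hydrogen in place of methyl on an oxygen on an aromatic ring makes an at least 7.2-fold higher number from compound 2 to compound 3 (0.86 log units; beyond the scatter). The change closest to the one at issue, 3,4-dichlorophenyl in place of 3-(trifluoromethyl)phenyl on an amide-type nitrogen, gives a step that the two limits leave unreadable from compound 1 to compound 3, so it offers no measured size.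

Compound 4 (`O=C(Nc1cccc(-n2cc(-c3ccncc3)c(-c3ccc(Cl)c(O)c3)n2)c1)Nc1ccc(Cl)c(C(F)(F)F)c1`) carries trifluoromethyl in place of chloro on an aromatic carbon of compound 3: trifluoromethyl in place of chloro on an aromatic carbon. This turns 3,4-dichlorophenyl into 4-chloro-3-(trifluoromethyl)phenyl. Compound 4 keeps the hydrogen on the oxygen, the feature tied to an at least 7.2-fold higher number from compound 2 to compound 3 (0.86 log units; beyond the scatter), so no recovery of growth inhibition is expected. The expected result is an at least 1.0-fold lower number from compound 3 to compound 4 (0.03 log units; that floor lies within the scatter), which means no step beyond the scatter in either direction. Compound 4 is estimated at 30000 nM, within a range of 12000 nM to 40000 nM, and will most likely be reported only as a limit.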

Compound 4, concentration for total growth inhibition: > 32500 nM
Compound 4 gave a limit, no number (the forecaster's own chance of this, stated with the estimate: 75%); middle value at least 1.0-fold (0.03 log units) from the limit.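

Compound 4 gives only a limit, as do compound 3 and compound 1, so the steps from compound 3 and from compound 1 to compound 4 cannot be read. The compounds shown leave open what size, if any, trifluoromethyl in place of chloro on an aromatic carbon has in this assay.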